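A few compounds are considered here, and "the series" means these few. Any claim that something is new, unique, unknown or untested is made for them only; others in the source may bear on it.

Series notes. The shared core is that of compound 1, `COc1ccc(N)c(C2=NN(C(C)=O)C(C)(C)S2)c1`; in an assay on isolated protein for inhibition of Nitric oxide synthase, inducible (Homo sapiens), read by scintillation counting, with a stated time of 30 min, tested at 50 uM (a higher number here means more inhibition at the concentration tested (going by the name of the read-out), a lower number less inhibition), compound 1 gives 77.1%. Compound 2, `CCCC(=O)N1N=C(c2cc(OC)ccc2N)SC1(C)C`, gives 91.1%, and compound 3, `CC(=O)N1N=C(c2cc(Cl)ccc2N)SC1(C)C`, gives 72.8%. Compound 3 carries the lowest of the three numbers, but its gap to compound 1 is within the scatter, so those two cannot be ordered; only compound 2 stands apart. The two measured steps are a number 14 percentage points higher from compound 1 to compound 2 (beyond the scatter) and a number 4.3 percentage points lower from compound 1 to compound 3 (within the scatter).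

Compound 4, `CC1(C)SC(c2cc(Cl)ccc2N)=NN1C(=O)C1CC1`, differs from compound 3 in one place: cyclopropyl in place of methyl on a carbonyl carbon. Among the measured compounds shown here, no measured pair swaps a methyl for a cyclopropyl. For the measured compounds named here, the only step that bears on it is the one that also changes the group on the same carbonyl carbon, a number 14 percentage points higher from compound 1 to compound 2 (beyond the scatter), which lay beyond the scatter. A rise of comparable but somewhat smaller size is therefore expected here, namely a number 11.2 percentage points higher from compound 3 to compound 4 (beyond the scatter). Compound 4 is thus estimated at 84%, with a range from 72% to 94%.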

Compound 4, a percentage reported as inhibition, at one concentration (the size of the read-out at that concentration, not a potency): 23.2%
The estimate for compound 4 lay 60.8 percentage points above the measured number, outside the stated range (below it).
By their numbers in this assay, from the lowest: compound 4; then compounds 3 and 1 (each within the scatter of the next); then compound 2.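

On the carbonyl carbon bound to the amide-type nitrogen in a ring, acetyl to cyclopropylcarbonyl gives a number 49.6 percentage points lower from compound 3 to compound 4 (beyond the scatter) in this assay, so changes at this place can lower the number sharply as well as raise it. The earlier step on the same acyl group, a number 14 percentage points higher from compound 1 to compound 2 (beyond the scatter), points the other way, so added carbon there does not by itself raise the number, and compound 4 goes against any such pattern. Nothing available explains the drop.

Going by these compounds, the two steps start from different aromatic substituents, chloro and methoxy, so it remains open whether cyclopropylcarbonyl would have the same effect with methoxy in place of chloro. Also open, on these data alone, is whether the loss follows the three-membered ring itself, which an isopropyl or cyclobutyl group on the same carbonyl carbon would test.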